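Swapping the anilino aryl group on a shared core

A few compounds are considered here, and "the series" means these few. Any claim that something is new, unique, unknown or untested is made for them only; others in the source may bear on it.

Measured compounds:
- compound 1 `CC(C)c1ccc(-c2nc(SCc3cn(CC(=O)NC(=O)Nc4ccccn4)nn3)nc(Nc3cccc(C(F)(F)F)c3)c2C#N)cc1`: 8620 nM
- compound 2 `Cc1ccc(Nc2nc(SCc3cn(CC(=O)NC(=O)Nc4ccccn4)nn3)nc(-c3ccc(Br)cc3)c2C#N)cc1`: 14400 nM

Both compounds were tested in a functional assay on MCF7 cells (Homo sapiens) for inhibition, read by MTT assay, with a stated time of 72 h; on this read-out higher numbers stand for weaker inhibition and lower numbers for stronger inhibition. Within the data shown here, compound 2 gives 14400 nM, the higher of the two numbers; the only other number, from compound 1 at 8620 nM, lies within the scatter of it, so the two cannot be told apart.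

Compound 3 `N#Cc1c(Nc2cccc(C(F)(F)F)c2)nc(SCc2cn(CC(=O)NC(=O)Nc3ccccn3)nn2)nc1-c1ccc(Br)cc1` is not yet measured. It differs from compound 2 in one place: 3-(trifluoromethyl)phenyl in place of 4-methylphenyl on a nitrogen on an aromatic ring. The rest of the molecule, including the bromophenyl group and the triazole-linked side chain, is unchanged.

Among the measured compounds shown here, no measured pair shows this exact change on its own. For the measured compounds named here, the only guide is compound 1, which already carries the 3-(trifluoromethyl)phenyl group on the same nitrogen and gives 8620 nM in this assay, a number within the scatter of compound 2. On that basis the step from compound 2 to compound 3 is expected to be small, a 1.4-fold lower number from compound 2 to compound 3 (0.16 log units; within the scatter), with no clear direction beyond the scatter. Compound 3 is therefore estimated at 10000 nM, within a range of 4000 nM to 25000 nM.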

Compound 3, half-maximal inhibitory concentration: 3110 nM
For compound 3 the middle estimate is 3.2-fold (0.51 log units) above the measured one; measured number below the stated range.
By their numbers in this assay, from the lowest: compound 3; then compounds 1 and 2 (each within the scatter of the next).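

In this assay the change on the nitrogen on an aromatic ring can now be read on its own: with the bromophenyl group held fixed, 3-(trifluoromethyl)phenyl in place of 4-methylphenyl gives a 4.6-fold lower number from compound 2 to compound 3 (0.67 log units; beyond the scatter) and this step lies beyond the usual scatter. With the 3-(trifluoromethyl)phenyl group held fixed, bromo in place of isopropyl on an aromatic carbon gives a 2.8-fold lower number from compound 1 to compound 3 (0.44 log units; beyond the scatter) and this step also lies beyond the scatter, so each of the two places moves the number when it is changed alone, something compound 1 and compound 2 could not show because they differ in both places at once. No measurement shown here accounts for either step.

Going by these compounds, each step rests on a single pair of compounds, so it remains open whether the change on the nitrogen would give a similar step with a group other than the bromophenyl group on the shared core. Also open, on these data alone, is how other groups would read in this assay, such as an unsubstituted phenyl or a butyl chain on the same nitrogen, or chloro or methoxy in place of bromo.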